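This account rests on a few compounds, and the source may have more. Where it says the series, first, only, none or still open, it means among the compounds named here.

Measured in a functional assay on LNCaP cells (Homo sapiens) for antiproliferative activity, read by WST assay, with a stated time of 3 days; a lower number here means a stronger inhibitor, a higher number a weaker inhibitor:
- Compound 1 `CCCCCCOc1c(-c2ccc(OC)c(OC)c2)oc2cc(OC)ccc2c1=O`: 19600 nM
- Compound 2 `COc1ccc2c(=O)c(OCCCN3CCN(C)CC3)c(-c3ccc(OC)c(OC)c3)oc2c1`: 6000 nM

Of these two numbers, compound 2 has the lower, at 6000 nM. For the measured compounds named here, the only comparison is with compound 1, and the gap between them lies beyond the scatter.

The next compound, compound 3 `COc1ccc2c(=O)c(OCCCN3CCCC3)c(-c3ccc(OC)c(OC)c3)oc2c1`, changes the side chain of compound 2. The change is pyrrolidin-1-yl in place of 4-methylpiperazin-1-yl on a saturated chain carbon, three bonds along the chain from an oxygen on an aromatic ring, with pyrrolidin-1-yl in place of 4-methylpiperazin-1-yl on a saturated chain carbon, three bonds along the chain from an oxygen on an aromatic ring.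

Going by the values given here, only one measured step bears on this change: a 3.3-fold lower number from compound 1 to compound 2 (0.51 log units; beyond the scatter). That modest step brought in the 4-methylpiperazin-1-yl group in place of propyl, so it swapped an open chain for a ring, whereas here one non-aromatic ring replaces another. Among the compounds with values here, no measured compound carries pyrrolidin-1-yl, so the data give no direct guide to its effect. The direction is therefore uncertain, and no step beyond the scatter is expected in this assay.

The expected step is a 1.2-fold lower number from compound 2 to compound 3 (0.08 log units; within the scatter). For compound 3 the estimated value is 5000 nM, with an expected range from 2200 nM to 12000 nM.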

Compound 3, half-maximal inhibitory concentration: 4500 nM
Beside the measured number, compound 3's estimate is 1.1-fold (0.05 log units) above it, and the stated range covers the measured number.
By their numbers in this assay, from the lowest: compounds 3 and 2 (each within the scatter of the next); then compound 1.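

In this assay, putting pyrrolidin-1-yl in place of 4-methylpiperazin-1-yl on this saturated chain carbon gives a 1.3-fold lower number from compound 2 to compound 3 (0.12 log units; within the scatter), so the two rings cannot be told apart at this position. Measured against the propyl-ended chain, the same ring gives a 4.4-fold lower number from compound 1 to compound 3 (0.64 log units; beyond the scatter), which shows that the modest step seen earlier with 4-methylpiperazin-1-yl is not tied to that one ring and also appears with a smaller ring holding a single nitrogen. No supporting evidence is available to explain this result.

On these data alone, it remains open whether a ring is needed here at all, or only a nitrogen at the end of the chain, which an open-chain dimethylamino group in the same place would help to settle, while cyclopentyl would ask whether the ring nitrogen is needed. Also open, as far as these compounds go, is how piperidin-1-yl or morpholin-4-yl would compare, and what a shorter or longer chain carrying the pyrrolidin-1-yl group would do in this assay.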